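Series notes: carbamate removal and a benzylic hydroxyl variant

This account rests on a few compounds, and the source may have more. Where it says the series, first, only, none or still open, it means among the compounds named here.

Measured compounds:
compound 1 `COC(=O)NC(CC(=O)N1CCC(Cn2c(C)nc3cnccc32)CC1)c1ccccc1`, 0.035 mg/kg
compound 2 `Cc1nc2cnccc2n1CC1CCN(C(=O)CCc2ccccc2)CC1`, > 5 mg/kg

In a functional assay on the whole organism (arterial blood) with Rattus norvegicus as the target (a higher number here means that more compound is needed for the effect, a lower number that less compound is needed), compound 1 gives 0.035 mg/kg. Compound 2 is reported only as a limit in this assay, > 5 mg/kg, so its number is not known; this is the point where the limit of > 5 mg/kg in this assay, at which 1 of the 2 values shown sits, applies. Going by the values given here, the one measured step, an at least 140-fold higher number from compound 1 to compound 2 (2.15 log units; beyond the scatter), shows that taking the (methoxycarbonyl)amino group away costs a great deal in this assay.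

The next compound is compound 3 `Cc1nc2cnccc2n1CC1CCN(C(=O)CC(C)(O)c2ccccc2)CC1`. It differs from compound 2 by 1-hydroxy-1-phenylethyl in place of benzyl on a saturated chain carbon bound to a carbonyl carbon. Among the compounds with values here, the change brings a hydrogen-bond donor and acceptor back to the same chain carbon that carried the (methoxycarbonyl)amino group in compound 1, but the group is not the carbamate of compound 1, so no measured step bears directly on it. Since compound 2 stands only at a limit, the step of an at least 1.6-fold lower number from compound 2 to compound 3 (0.22 log units; that floor lies within the scatter) is an expectation with little footing; a modest gain is thought possible, but a second limit is about as likely. Compound 3 is therefore estimated at 3 mg/kg, within 0.5 mg/kg to 15 mg/kg.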

Compound 3, dose for 50% inhibition: 0.043 mg/kg
Beside the measured number, compound 3's estimate is 70-fold (1.84 log units) above it, and the stated range ends above it.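

In this assay, 1-hydroxy-1-phenylethyl in place of benzyl on a saturated chain carbon bound to a carbonyl carbon gives an at least 110-fold lower number from compound 2 to compound 3 (2.06 log units; beyond the scatter), so the high requirement of compound 2 is not overcome by the (methoxycarbonyl)amino group alone, and the carbamate is not needed for a low dose at this carbon. Compound 1 gives 0.035 mg/kg and compound 3 gives 0.043 mg/kg, and no order is drawn between these two, so two quite different groups at this place both go with doses far under that of the unsubstituted chain. The size of the step is a floor and not a measured gap, as compound 2 is reported only as a limit: the limit of > 5 mg/kg in this assay, at which 1 of the 3 values shown sits.

The change brings in the hydroxyl and the extra methyl together, so the compounds shown do not tell which of the two carries the step, and a chain with the hydroxyl alone or the methyl alone would separate them. Going by these compounds, how far the position tolerates other groups also stays open, for instance a primary amine or a carboxylic acid on the same carbon.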